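Methoxy in place of hydrogen on the terminal phenyl

The source may hold more compounds than are shown below. What is called first, only, known or untested is meant among the compounds shown, and "the series" means these compounds.

Among the compounds with values here, compound 2 `O=C(Nc1ccccc1)Nc1ccc(NC2=NS(=O)(=O)c3ccccc32)cc1` stands lowest of the two numbers measured so far in a physicochemical assay for lipophilicity (a higher number here means a more lipophilic compound, a lower number a more polar compound), where compound 2 gives 2.23. Its nearest neighbour is compound 1 `O=C(Nc1ccc(NC2=NS(=O)(=O)c3ccccc32)cc1)Nc1cccc(Br)c1`, which in this assay gives 2.24. Within the data shown here, the single measured step, a number 0.01 log units lower from compound 1 to compound 2 (within the scatter), lies within the scatter. Compound 3 `COc1ccc(NC(=O)Nc2ccc(NC3=NS(=O)(=O)c4ccccc43)cc2)cc1` has not been measured. It differs from compound 2 by methoxy in place of hydrogen on an aromatic carbon, the new group sitting on an aromatic carbon of a six-membered aromatic ring of carbon only, para to a large group. Among the measured compounds shown here, the only step that bears on this change is the bromo-to-hydrogen exchange, which is also a swap of substituent on an aromatic carbon and moved the number by nothing beyond the scatter. A step beyond the scatter is therefore not expected here in either direction, and the expected step of a number 0.03 log units lower from compound 2 to compound 3 (within the scatter) is taken as small. For compound 3 the estimate in this assay is 2.2, with a range from 1.8 to 2.6.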

Compound 3, partition coefficient: 2.99
For compound 3 the middle estimate is 0.79 log units below the measured one; measured number above the stated range.
By their numbers in this assay, from the lowest: compounds 2 and 1 (each within the scatter of the next); then compound 3.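

Placed on an aromatic carbon of the terminal ring, para to a large group, methoxy gives the first step in the series beyond the scatter in this assay (a number 0.76 log units higher from compound 2 to compound 3 (beyond the scatter)). The exchange of 3-bromophenyl for 4-methoxyphenyl on the amide-type nitrogen also gives a step beyond the scatter (a number 0.75 log units higher from compound 1 to compound 3 (beyond the scatter)), so the terminal ring is not indifferent to what it carries, and the earlier bromo-to-hydrogen exchange does not speak for every substituent. No measurement at hand bears on why methoxy gives this step.

From the compounds shown here alone, it remains open whether this step belongs to methoxy specifically or extends to other groups at the same carbon, such as hydroxy, ethoxy, an amine or a carboxylic acid. Going by these compounds, it also remains open whether methoxy on another carbon of this ring would give a step of similar size.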